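The source may report more compounds than this note shows. Statements on the series, on what has been measured and on what is new or still open speak of the compounds shown alone.

Measured compounds in this series:

compound 1, `O=C(Nc1cccc(-c2nc3ccccc3s2)c1)c1cnccc1Cl`: 320 nM
compound 2, `Cc1ccc(-c2nc3ccccc3s2)cc1NC(=O)c1cnccc1Cl`: 140 nM
compound 3, `COc1ccc(-c2nc3ccccc3s2)cc1NC(=O)c1cnccc1Cl`: 340 nM

Within the data shown here, in a physicochemical assay for solubility, in phosphate buffer, measured as kinetic solubility, with a stated time of 18 h, at pH 7.4 (a lower number here means a less soluble compound, a higher number a more soluble compound), compound 3 stands at the top of the three numbers, but only the step of a 2.4-fold higher number from compound 2 to compound 3 (0.39 log units; beyond the scatter) lies beyond the scatter; the step of a 1.1-fold higher number from compound 1 to compound 3 (0.03 log units; within the scatter) lies within it, so compound 3 and compound 1 cannot be told apart in this assay. The remaining step, a 2.3-fold lower number from compound 1 to compound 2 (0.36 log units; beyond the scatter), is modest and runs downward.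

Compound 4, `COc1ccc(-c2nc3ccccc3o2)cc1NC(=O)c1cnccc1Cl`, differs from compound 3 in one place: 1,3-benzoxazol-2-yl in place of 1,3-benzothiazol-2-yl on an aromatic carbon. None of the three measured steps touches this part of the molecule; each of them concerns the group on the other ring of the shared core, where methyl or methoxy replaced hydrogen or one replaced the other. Among the measured compounds shown here, there is therefore no measured step that bears directly on the exchange of the sulfur-containing bicycle for the oxygen-containing one, and nothing in the data points to a shift of a size beyond the scatter. Compound 4 is accordingly expected to show a step of a 1.2-fold higher number from compound 3 to compound 4 (0.07 log units; within the scatter) in this assay. The estimate for compound 4 is 400 nM, with a range from 150 nM to 1000 nM.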

Compound 4, solubility: 1680 nM
Compound 4: the middle estimate sits 4.2-fold (0.62 log units) below what was measured, outside the stated range (above it).
By their numbers in this assay, from the lowest: compound 2; then compounds 1 and 3 (each within the scatter of the next); then compound 4.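

In this assay, among these compounds, exchanging 1,3-benzothiazol-2-yl for 1,3-benzoxazol-2-yl gives a 4.9-fold higher number from compound 3 to compound 4 (0.69 log units; beyond the scatter), a larger step than a 2.4-fold higher number from compound 2 to compound 3 (0.39 log units; beyond the scatter), which is the largest of the earlier steps upward. The earlier compounds shown here all carried 1,3-benzothiazol-2-yl, so they could show only what happened when hydrogen, methyl or methoxy changed on the shared core; this result shows that the number also responds to the group on an aromatic carbon, meta to a large group and para to a methoxy group, and that it does so although the two groups have the same counts of heavy atoms, rings, hydrogen-bond donors and acceptors and differ only in oxygen for sulfur. No measurement shown here explains why this single-atom exchange gives a step of this size.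

Among the compounds shown here, whether the exchange gives a step of similar size with hydrogen or methyl in place of the methoxy group remains open, since compound 3 and compound 4 are the only pair that shows it. Also open, as far as these compounds go, is how the number would respond to an amine or a carboxylic acid on the 1,3-benzoxazol-2-yl group.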